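Working notes: chloro to methyl exchange next on compound 2

A few compounds are considered here, and "the series" means these few. Any claim that something is new, unique, unknown or untested is made for them only; others in the source may bear on it.

Measured so far:
compound 1 `Oc1cccc(CNc2cc(Br)cc3[nH]ncc23)c1`, 55%
compound 2 `Oc1ccc(CNc2cc(Br)cc3[nH]ncc23)cc1Cl`, 19%

In an assay for inhibition of Tryptophan 2,3-dioxygenase (Homo sapiens), with a stated time of 1 h, tested at 10 uM (on this read-out higher numbers stand for more inhibition at the one concentration tested (going by the name of the read-out) and lower numbers for less inhibition), compound 1 gives 55% and compound 2 gives 19%, the lower of the two numbers, with compound 1 standing higher by a gap beyond the usual scatter. Compound 3 `Cc1cc(CNc2cc(Br)cc3[nH]ncc23)ccc1O` is not yet measured; it differs from compound 2 as follows: methyl in place of chloro on an aromatic carbon. Among the measured compounds shown here, no step between measured compounds bears on this exchange, so the expectation rests on compound 2 alone. The expected step of a number 6 percentage points higher from compound 2 to compound 3 (within the scatter) in this assay is small, at most modestly upward, and may fall within the scatter. Compound 3 is accordingly estimated at 25%, with a range from 5% to 50%.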

Compound 3, a percentage reported as inhibition, at one concentration (the size of the read-out at that concentration, not a potency): 30%
Compound 3: middle estimate off by 5 percentage points, on the low side, within the range that was stated.
By their numbers in this assay, from the lowest: compound 2; then compound 3; then compound 1.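

In this assay, methyl in place of chloro on the aromatic carbon ortho to a hydroxy group gives a number 11 percentage points higher from compound 2 to compound 3 (beyond the scatter), so this position is not indifferent to the exchange. Chloro and methyl have the same heavy-atom count and no hydrogen-bond donors or acceptors, yet the read-out separates them. No measurement at hand bears on why the two groups differ. Open, on these data alone, is how a methoxy group, an amine or a carboxylic acid on this carbon would read, and whether the exchange gives a similar step with the hydroxy group placed elsewhere.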